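Carbonyl substituent variation: notes toward compound 3

The source may hold more compounds than are shown below. What is called first, only, known or untested is meant among the compounds shown, and "the series" means these compounds.

Compound 1 `Cc1cccc(Cn2c(CN3CCN(C(=O)c4ccc([N+](=O)[O-])cc4)CC3)nc3ccccc32)c1` gives 24.3% in an assay on isolated protein for inhibition of aldehyde dehydrogenase 1A1 (Homo sapiens), read by spectrophotometry, tested at 10 uM; a higher number here means more inhibition at the concentration tested (going by the name of the read-out), a lower number less inhibition. Compound 2 `Cc1cccc(Cn2c(CN3CCN(C(=O)CC(C)C)CC3)nc3ccccc32)c1` gives 71.4% in this assay and stands highest of the two measured numbers, with compound 1 the nearest. Among the measured compounds shown here, the only measured step, a number 47.1 percentage points higher from compound 1 to compound 2 (beyond the scatter), concerns the same carbonyl carbon. Compound 3 `Cc1cccc(Cn2c(CN3CCN(C(=O)c4ccncc4)CC3)nc3ccccc32)c1` differs from compound 2 by pyridin-4-yl in place of isobutyl on a carbonyl carbon. The measured step traded an aromatic ring on that carbonyl carbon for isobutyl and the number rose; compound 3 returns an aromatic ring to the same place, so a fall beyond the scatter is expected, although pyridin-4-yl is not 4-nitrophenyl and a single step is thin support. Compound 3 is therefore expected at 35% (range 15% to 60%), a step of a number 36.4 percentage points lower from compound 2 to compound 3 (beyond the scatter).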

Compound 3, a percentage reported as inhibition, at one concentration (the size of the read-out at that concentration, not a potency): 20.6%
The estimate for compound 3 lay 14.4 percentage points above the measured number; low and high end bracket the measured number.
By their numbers in this assay, from the lowest: compounds 3 and 1 (each within the scatter of the next); then compound 2.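

In this assay, isobutyl on the carbonyl carbon now stands apart from two different aromatic rings: pyridin-4-yl in its place gives a number 50.8 percentage points lower from compound 2 to compound 3 (beyond the scatter). Exchanging 4-nitrophenyl for pyridin-4-yl gives a number 3.7 percentage points lower from compound 1 to compound 3 (within the scatter), so the two aromatic groups are not separated at this position. No measured evidence on hand accounts for the gap between isobutyl and these rings. Still open, from the compounds shown here alone, is whether the higher number belongs to isobutyl alone or to open-chain groups generally; cyclohexyl or a longer chain such as n-pentyl on the same carbonyl carbon would test this.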